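The source may hold more compounds than are shown below. What is called first, only, known or untested is meant among the compounds shown, and "the series" means these compounds.

Working notes on the series.

Two compounds share the same core, a bis(trifluoromethyl)phenylsulfonamide joined through a short amine-bearing chain to a substituted benzyl group. Compound 1 is `CC(C)(C)c1ccc(CNCCNS(=O)(=O)c2cc(C(F)(F)F)cc(C(F)(F)F)c2)cc1` and compound 2 is `O=S(=O)(NCCCNCc1cccc(Cl)c1)c1cc(C(F)(F)F)cc(C(F)(F)F)c1`. In a functional assay on Capan-2 cells (Homo sapiens) for inhibition, read by MTT assay, with a stated time of 72 h (a higher number here means a weaker inhibitor of growth, a lower number a stronger inhibitor of growth), compound 1 gives 13000 nM and compound 2 gives 8000 nM; the gap between these two numbers lies within the usual scatter, so neither compound stands apart from the other on the data to hand.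

Compound 3, `O=S(=O)(NCCCNCc1ccc(Cl)c(Cl)c1)c1cc(C(F)(F)F)cc(C(F)(F)F)c1`, is not yet measured. Relative to compound 2 the change is chloro in place of hydrogen on an aromatic carbon. Going by the values given here, no comparable step between measured compounds exists in this set, so the direction rests on the structural change alone. A modest move to a lower number in this assay is expected, of a size that may not clear the scatter. For compound 3 the estimated value is 5000 nM, with a range from 2000 nM to 12000 nM, corresponding to an expected step of a 1.6-fold lower number from compound 2 to compound 3 (0.20 log units; within the scatter).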

Compound 3, concentration for 50% growth inhibition: 1800 nM
Beside the measured number, compound 3's estimate is 2.8-fold (0.44 log units) above it; the measured number lies below the stated range.
By their numbers in this assay, from the lowest: compound 3; then compounds 2 and 1 (each within the scatter of the next).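

In this assay, chloro in place of hydrogen on the aromatic carbon ortho to a chloro group and para to a large group gives a 4.4-fold lower number from compound 2 to compound 3 (0.65 log units; beyond the scatter). Going by these compounds alone, this is the only one-place step, and it shows that the position on the 3-chlorobenzyl group is sensitive to this change, which compounds 1 and 2 could not show because they differ in more than one place. No measurement at hand bears on the origin of this step.

Still open, as far as these compounds go, is whether the step is specific to chloro or would also appear with fluoro, methyl or methoxy at this position. The compounds shown also do not tell whether a 4-chlorobenzyl group without the existing chloro, or a 3,4-dichlorobenzyl group on the chain of compound 1, would give a similar number.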